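The compounds below may be only part of what the source reports. "The series", "measured", "known", "first", "only" and "open" are said of these compounds alone.

Measured so far in an ADME assay on BJ cells (Homo sapiens), read by MTT assay, with a stated time of 72 h; a higher number here means a weaker inhibitor, a lower number a stronger inhibitor:

Compound 1 `Cc1nc(N)c2c(-c3cccs3)cn([C@@H]3O[C@H](CO)[C@@H](O)[C@H]3O)c2n1`. In this assay compound 1 gives > 100000 nM, which is a limit of the assay and not a number.
Compound 2 `Nc1nc2c(c(-c3cccs3)cn2[C@@H]2O[C@H](CO)[C@@H](O)[C@H]2O)c(=O)[nH]1`. In this assay compound 2 gives > 100000 nM, likewise a limit of the assay.
Compound 3 `Cc1nc(N)c2c(-c3ccoc3)cn([C@@H]3O[C@H](CO)[C@@H](O)[C@H]3O)c2n1`. In this assay compound 3 gives > 100000 nM, again only a limit.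

The difference between the core of compound 1 and the core of compound 2 is not broken down here. From compound 1 to compound 3 the change is furan-3-yl in place of thiophen-2-yl on an aromatic carbon. The step that the two limits leave unreadable from compound 1 to compound 3 cannot be sized because of the limit of > 100000 nM in this assay, at which 3 of the 3 values shown sit.

Compound 4 `Nc1nc2c(c(-c3ccoc3)cn2[C@@H]2O[C@H](CO)[C@@H](O)[C@H]2O)c(=O)[nH]1` is not yet measured. It differs from compound 2 by furan-3-yl in place of thiophen-2-yl on an aromatic carbon, the same change at the same place. The step is expected to stay flat, a step that the limit leaves unreadable from compound 2 to compound 4. This rests on compound 1 and compound 3, whose step that the two limits leave unreadable from compound 1 to compound 3 is unreadable because of the limit of > 100000 nM in this assay, at which 3 of the 3 values shown sit. Compound 4 is expected to give about 150000 nM in this assay, most probably reported only as a limit.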

Compound 4, half-maximal inhibitory concentration: 21500 nM
Estimate against measurement, compound 4: 7.0-fold (0.84 log units) above; measured number below the stated range.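

In this assay, furan-3-yl in place of thiophen-2-yl gives an at least 4.6-fold lower number from compound 2 to compound 4 (0.66 log units; beyond the scatter), so the change has a readable effect on this core, and its true size may be larger since the starting value is a limit. The same change on the core of compound 1 leaves no readable step, and the two steps cannot be compared because the values there are limits: the limit of > 100000 nM in this assay, at which 3 of the 4 values shown sit. Carrying the change from one core to another is therefore neither supported nor ruled out by these pairs.

Still open, on these data alone, is how a phenyl ring, furan-2-yl or an aminomethyl group would read at the same place in this assay. Also open, as far as these compounds go, is whether any such group would bring the core of compound 1 to a measurable value.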